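The source may report more compounds than this note shows. Statements on the series, on what has been measured and on what is new or still open speak of the compounds shown alone.

Working notes on the series, all read in a functional assay on A2780 cells (Homo sapiens) for antiproliferative activity, read by resazurin assay, with a stated time of 72 h; a lower number here means a stronger inhibitor, a higher number a weaker inhibitor. Going by the values given here, three compounds share the core, and only two of them carry numbers. Compound 1 (`Cc1ccc(CN(C)C(=O)c2cc3c(Cc4ccccc4)n[nH]c3cc2O)cc1`) gives 6900 nM, and compound 3 (`CN(Cc1cccc(NS(C)(=O)=O)c1)C(=O)c1cc2c(Cc3cccc(Cl)c3)n[nH]c2cc1O`) gives 3200 nM. Compound 2 (`CN(Cc1ccccc1)C(=O)c1cc2c(Cc3ccccc3Cl)n[nH]c2cc1O`) stands without a number: its entry reads "not determined" (no result reported), so it offers no starting value for the next comparison.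

Compound 4 (`CCc1ccc(Cc2n[nH]c3cc(O)c(C(=O)N(C)Cc4ccccc4)cc23)cc1`) differs from compound 2 in one place: 4-ethylphenyl in place of 2-chlorophenyl on a saturated chain carbon bound to an aromatic carbon. Among the compounds with values here, no measured compound here carries the 4-ethylphenyl group, and no measured step in this assay covers this change. A step from compound 2 therefore cannot be sized, and no direction can be assigned to it. The expectation rests on the two numbers available, compound 1 at 6900 nM and compound 3 at 3200 nM, and compound 4 is expected to fall in their region.

For compound 4 the estimated value is 5000 nM, with an expected range of 1800 nM to 14000 nM.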

Compound 4, half-maximal inhibitory concentration: > 10000 nM
Compound 4: only a limit was reported; the forecaster's own chance of this, stated with the estimate: 10%; at least 2.0-fold (0.30 log units) between middle value and limit.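

Compound 2 carries no number and compound 4 gives > 10000 nM, which is a limit and not a number, so no new step can be read between them. From the compounds shown here alone, the size of the change from 2-chlorophenyl to 4-ethylphenyl in this assay stays open.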